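A few compounds are considered here, and "the series" means these few. Any claim that something is new, unique, unknown or untested is made for them only; others in the source may bear on it.

Compound 3 `C/C(=C\C(=O)Nc1ccccc1OCCCC(=O)O)c1ccc2c(ccn2Cc2ccc(C(C)(C)C)cc2)c1` gives 170 nM in an assay on Prostate gland for inhibition of steroid 5-alpha-reductase (Rattus norvegicus) (a lower number here means a stronger inhibitor, a higher number a weaker inhibitor), the highest of the three numbers measured, though both other compounds lie within the scatter of it: compound 1 `CC(C)=CCn1ccc2cc(/C(C)=C/C(=O)Nc3ccccc3OCCCC(=O)O)ccc21` gives 120 nM and compound 2 `C/C(=C\C(=O)Nc1ccccc1OCCCC(=O)O)c1ccc2c(ccn2Cc2ccc(C)cc2)c1` gives 88 nM. The steps of a 1.4-fold lower number from compound 1 to compound 2 (0.13 log units; within the scatter), a 1.4-fold higher number from compound 1 to compound 3 (0.15 log units; within the scatter) and a 1.9-fold higher number from compound 2 to compound 3 (0.29 log units; within the scatter) all stayed within the scatter, so none of the three exchanges on the saturated chain carbon bound to an aromatic nitrogen, or on the aromatic carbon of the ring it carries, moved the number in a clear way. Compound 4 `COc1ccc(Cn2ccc3cc(/C(C)=C/C(=O)Nc4ccccc4OCCCC(=O)O)ccc32)cc1` differs from compound 3 by methoxy in place of tert-butyl on an aromatic carbon. The step that bears most directly on this change is a 1.9-fold higher number from compound 2 to compound 3 (0.29 log units; within the scatter), where one group replaced another on the same aromatic carbon without a shift beyond the scatter, and the other two steps point the same way. A further exchange at that carbon is therefore expected to give a 1.4-fold lower number from compound 3 to compound 4 (0.15 log units; within the scatter), with no direction beyond the scatter. Compound 4 is estimated at 120 nM in this assay, within a range from 55 nM to 260 nM.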

Compound 4, half-maximal inhibitory concentration: 480 nM
The estimate for compound 4 lay 4.0-fold (0.60 log units) below the measured number; measured number outside the range, above it.
By their numbers in this assay, from the lowest: compounds 2, 1 and 3 (each within the scatter of the next); then compound 4.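

In this assay, no earlier exchange on this aromatic carbon had moved the number beyond the scatter, yet methoxy in place of tert-butyl gives a 2.8-fold higher number from compound 3 to compound 4 (0.45 log units; beyond the scatter) and methoxy in place of methyl gives a 5.5-fold higher number from compound 2 to compound 4 (0.74 log units; beyond the scatter) at the same place. The position therefore does respond to its substituent: methyl and tert-butyl stay within the scatter of each other, while methoxy, the only one of the three with an oxygen and a hydrogen-bond acceptor, stands apart from both. Compound 4 also stands apart from the compound with the 2-methylprop-1-en-1-yl group, with 4-methoxyphenyl in its place giving a 4.0-fold higher number from compound 1 to compound 4 (0.60 log units; beyond the scatter) on the saturated chain carbon bound to an aromatic nitrogen.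

A hydroxy, ethoxy or chloro group on the same aromatic carbon would help show whether the shift follows the oxygen or something else about methoxy. The compounds shown cannot settle this, and no measurement offered here accounts for the shift.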